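The source may report more compounds than this note shows. Statements on the series, on what has been measured and on what is new or still open speak of the compounds shown alone.

Measured compounds:
compound 1, `O=C(Nc1cccc(-n2cc(-c3ccncc3)c(-c3ccc(Cl)c(O)c3)n2)c1)Nc1cccc(C(F)(F)F)c1`, in a functional assay on CCRF-CEM cells (Homo sapiens) for inhibition, read by sulforhodamine B assay, with a stated time of 48 h; a higher number here means a weaker inhibitor of growth, a lower number a stronger inhibitor of growth: > 32500 nM
compound 2, `COc1cc(-c2nn(-c3cccc(NC(=O)c4cccc(C(F)(F)F)c4)c3)cc2-c2ccncc2)ccc1Cl`, in this assay: > 50000 nM

Both numbers are limits of the assay rather than measured concentrations. For compound 1 the value > 32500 nM is a limit, so no growth inhibition was reached within the tested range (the limit of > 32500 nM in this assay, at which 1 of the 2 values shown sits). For compound 2 the value > 50000 nM is likewise a limit (the limit of > 50000 nM in this assay, at which 1 of the 2 values shown sits). Compound 1 therefore stands at the limit itself, and the other value shown is also a limit, so there is no measured number to place it against.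

Compound 3, `O=C(Nc1cccc(-n2cc(-c3ccncc3)c(-c3ccc(Cl)c(O)c3)n2)c1)Nc1ccc(Cl)c(Cl)c1`, differs from compound 1 in one place: 3,4-dichlorophenyl in place of 3-(trifluoromethyl)phenyl on an amide-type nitrogen. Among the measured compounds shown here, no step between measured compounds is available for this change. Since compound 1 gave only a limit, the expectation is that compound 3 will also show no growth inhibition within the tested range, with no step beyond the scatter expected in this assay a step that the limit leaves unreadable from compound 1 to compound 3. Compound 3 is thus estimated at 40000 nM, within 15000 nM to 100000 nM, most likely reported again as a limit.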

Compound 3, concentration for total growth inhibition: > 32500 nM
Compound 3 gave a limit, no number; the forecaster's own chance of this, stated with the estimate: 80%; the middle value is on the limit's open side.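

In this assay compound 3 gives > 32500 nM, which is a limit. Among the compounds shown here, compound 1 gives > 32500 nM, also a limit, and no step from compound 1 to compound 3 can be read. The compounds shown leave open whether 3,4-dichlorophenyl in place of 3-(trifluoromethyl)phenyl changes growth inhibition at all.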